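The source may report more compounds than this note shows. Statements on the series, on what has been measured and on what is new or still open speak of the compounds shown alone.

Going by the values given here, in a functional assay on THP-1 cells (Homo sapiens) for cytotoxicity, read by MTT assay, with a stated time of 24 h (a lower number here means a stronger inhibitor, a higher number a weaker inhibitor), only two compounds have been measured so far. Compound 1 `COc1cc(/C=C2\CN(C)C/C(=C\c3ccc(F)cc3)C2=O)cc(OC)c1OC` gives 6130 nM. Compound 2 `COc1cc(/C=C2\CN(C)C/C(=C\c3ccc(Cl)cc3)C2=O)cc(OC)c1OC` gives 7200 nM, which places it level with compound 1, as the two numbers lie within the scatter of each other. The next compound, compound 3 `COc1cc(/C=C2\CN(C)C/C(=C\c3ccc(Br)cc3)C2=O)cc(OC)c1OC`, keeps the shared core and alters a single group: bromo in place of chloro on an aromatic carbon. This places bromo in place of chloro on an aromatic carbon, para to a large group, so that 4-chlorophenyl becomes 4-bromophenyl. Among the compounds with values here, only one measured step bears on this change, namely chloro in place of fluoro on an aromatic carbon, and it amounts to a 1.2-fold higher number from compound 1 to compound 2 (0.07 log units; within the scatter). Within the data shown here, that single step is small, but it is the only guide available, and no measured compound yet carries bromo. No change beyond the scatter is therefore expected in this assay. The expected size of the change is a 1.0-fold higher number from compound 2 to compound 3 (0.02 log units; within the scatter). Compound 3 is estimated to give 7500 nM, with an expected range from 4500 nM to 12500 nM.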

Compound 3, half-maximal inhibitory concentration: 5330 nM
Estimate against measurement, compound 3: 1.4-fold (0.15 log units) above, within the range that was stated.
By their numbers in this assay, from the lowest: compounds 3, 1 and 2 (each within the scatter of the next).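

In this assay, bromo extends the comparison at this place, on an aromatic carbon para to a large group, to a third halogen: the exchange of 4-chlorophenyl for 4-bromophenyl gives a 1.4-fold lower number from compound 2 to compound 3 (0.13 log units; within the scatter) and stays level. Bromo in place of fluoro, the widest exchange among the halogens shown, gives a 1.2-fold lower number from compound 1 to compound 3 (0.06 log units; within the scatter), so that fluoro, chloro and bromo all read alike here, whereas the earlier pair had shown this only for fluoro and chloro. Nothing available explains why the three halogens read alike, and the result speaks only to cytotoxicity on these cells.

The compounds leave open whether this tolerance reaches beyond halogens, since a hydrogen, a methoxy group, an amine or a carboxylic acid at this place might read quite differently from the three shown. They also leave open whether a halogen would read the same at another place on this ring, or whether any change to the rest of the shared core would move the numbers beyond the scatter.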